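This account rests on a few compounds, and the source may have more. Where it says the series, first, only, none or still open, it means among the compounds named here.

Series notes

Three members of the series have been run in an assay on HEK293 cells for antagonist activity at transient receptor potential cation channel subfamily V member 3 (Homo sapiens), read by FLIPR and calcium flux; a lower number here means a stronger inhibitor, a higher number a weaker inhibitor. Compound 1 `O[C@H](c1ccccn1)[C@]1(c2cccc(OC(F)(F)F)c2)C[C@H](O)C1` gives 40 nM in this assay. Compound 2 `O[C@H](c1ccccn1)[C@]1(c2cccc(C(F)(F)F)c2)C[C@H](O)C1` gives 90 nM. Compound 3 `C[C@]1(O)C[C@@](c2cccc(C(F)(F)F)c2)([C@H](O)c2ccccn2)C1` gives 300 nM, the highest of the three numbers.

Compound 1 and compound 2 share a core and differ in one place, (trifluoromethoxy in place of trifluoromethyl on an aromatic carbon). This change gives a 2.3-fold lower number from compound 2 to compound 1 (0.35 log units; beyond the scatter). The core of compound 3 is not the same as that of compound 2, and the difference between the two cores is not broken down here; the two values simply show that compound 3 stands higher than compound 2 in this assay.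

Compound 4 `C[C@]1(O)C[C@@](c2cccc(OC(F)(F)F)c2)([C@H](O)c2ccccn2)C1` has the core of compound 3 and carries the same change, (trifluoromethoxy in place of trifluoromethyl on an aromatic carbon). The change enters at the same place as in the pair already measured. Within the core of compound 1 and compound 2 that change made a modest step in this assay, and the same step is the only basis for what follows.

Among the compounds with values here, for compound 4 a step of a 2.3-fold lower number from compound 3 to compound 4 (0.36 log units; beyond the scatter) in this assay is expected, resting on compound 2 and compound 1 with a 2.3-fold lower number from compound 2 to compound 1 (0.35 log units; beyond the scatter) as the only measured instance of this change. Within the data shown here, compound 4 is therefore estimated at 130 nM in this assay, with a range from 60 nM to 280 nM to allow for the usual scatter and for the core being different from the one in which the change was measured.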

Compound 4, antagonist equilibrium constant: 280 nM
For compound 4 the middle estimate is 2.2-fold (0.33 log units) below the measured one; measured number inside the range.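

Within the data shown here, on the core of compound 3, trifluoromethoxy in place of trifluoromethyl on an aromatic carbon gives a 1.1-fold lower number from compound 3 to compound 4 (0.03 log units; within the scatter) in this assay, so on this core the change shows no step that can be told from repeated measurement. Set beside the step on the core of compound 1 and compound 2, this result does not separate the two cores: the same change on two cores in this assay, a 2.3-fold lower number (0.35 log units; beyond the scatter) from compound 2 to compound 1 and a 1.1-fold lower number (0.03 log units; within the scatter) from compound 3 to compound 4, 2.1-fold (0.32 log units) apart, within the scatter of two such steps The two pairs therefore show neither that the change carries over from one core to another with a constant size nor that its size depends on the core, since each core offers a single pair and the gap between the two steps is no larger than scatter alone would allow.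

The compounds shown leave open how other groups on the same aromatic carbon, such as a chlorine atom, a methoxy group or a nitrile, would read in this assay, and whether any of them would behave alike on both cores. Also open, from the compounds shown here alone, is what an amine or a carboxylic acid in place of a hydroxyl group would do, and whether a third core carrying the same pair of groups would help settle how well this change transfers across the series.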